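A few compounds are considered here, and "the series" means these few. Any claim that something is new, unique, unknown or untested is made for them only; others in the source may bear on it.

Within the data shown here, compound 2 `O=C(CCCCCCc1nc(-c2ccc(F)cc2)no1)NO` is the only member of the set with a numerical value in an assay on isolated protein for inhibition of histone deacetylase 8 (Homo sapiens), read by fluorescence, with a stated time of 10 min; on this read-out lower numbers stand for stronger inhibition and higher numbers for weaker inhibition: in that assay compound 2 gives 8760 nM. Compound 1 `O=C(CCCCCCc1nc(-c2ccc(C(F)(F)F)cc2)no1)NO` carries trifluoromethyl in place of the fluoro of compound 2 on an aromatic carbon. In this assay compound 1 is reported only as a limit, > 10000 nM. Among the measured compounds shown here, the single measured step, an at least 1.1-fold lower number from compound 1 to compound 2 (0.05 log units; that floor lies within the scatter), therefore rests on the limit of > 10000 nM in this assay, at which 1 of the 2 values shown sits, and cannot be given a size beyond its floor. Compound 3 `O=C(CCCCCCc1nc(-c2ccc(F)cc2)no1)C(F)(F)F` differs from compound 2 in trifluoromethyl in place of hydroxyamino on a carbonyl carbon. For the measured compounds named here, no measured step touches the carbonyl carbon, so the aromatic comparison offers no guide to this change, and any expectation has to rest on where compound 2 itself stands. Compound 3 is expected to give 20000 nM in this assay, with a range from 5000 nM to 80000 nM. That expectation amounts to a step of a 2.3-fold higher number from compound 2 to compound 3 (0.36 log units; beyond the scatter), with a real chance that only a limit is reported.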

Compound 3, half-maximal inhibitory concentration: 7650 nM
Estimate against measurement, compound 3: 2.6-fold (0.42 log units) above; the measured number falls inside the stated range.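

In this assay, the carbonyl carbon now has its first measured change, and trifluoromethyl in place of hydroxyamino comes out as a 1.1-fold lower number from compound 2 to compound 3 (0.06 log units; within the scatter). The two groups differ in their counts, with hydroxyamino bringing 2 hydrogen-bond donors and trifluoromethyl none, yet this read-out does not separate the pair. Within this pair, then, inhibition at this level does not depend on keeping the hydroxycarbamoyl group, a point the aromatic comparison could not address.

From the compounds shown here alone, whether an amine or a hydroxyl on the same carbonyl carbon, or a longer chain, would read the same remains open. The aromatic comparison also stays without a size, as compound 1 is reported only as a limit: the limit of > 10000 nM in this assay, at which 1 of the 3 values shown sits.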